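One ring swap at the end of a shared core

This account rests on a few compounds, and the source may have more. Where it says the series, first, only, none or still open, it means among the compounds named here.

Compound 1 `COc1ccc(/C=N/NC(=O)Nc2ccc(Oc3ccnc(-c4nncn4CCN(C)C)c3)c(F)c2)c(OC)c1` gives 1680 nM in a functional assay on MKN-45 cells (Homo sapiens) for cytotoxicity, read by MTT assay, with a stated time of 72 h; a higher number here means a weaker inhibitor, a lower number a stronger inhibitor.
Compound 2 `CN(C)CCn1cnnc1-c1cc(Oc2ccc(NC(=O)N/N=C/c3ccccc3)cc2F)ccn1` gives 2730 nM in this assay.
Compound 3 `CN(C)CCn1cnnc1-c1cc(Oc2ccc(NC(=O)N/N=C/c3ccc(O)cc3)cc2F)ccn1` gives 820 nM in this assay.

Among these three numbers compound 1 stands second highest. Its gap to compound 2 is a 1.6-fold higher number from compound 1 to compound 2 (0.21 log units; within the scatter), so the two cannot be told apart, while the gap to compound 3 is a 2.0-fold lower number from compound 1 to compound 3 (0.31 log units; beyond the scatter), a modest gain for compound 3.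

Compound 4 `COc1cc(/C=N/NC(=O)Nc2ccc(Oc3ccnc(-c4nncn4CCN(C)C)c3)c(F)c2)ccc1O` differs from compound 1 in a single place: 4-hydroxy-3-methoxyphenyl in place of 2,4-dimethoxyphenyl on a carbon with a double bond to nitrogen

Two measured steps speak to this change. Adding a hydroxy to the ring gave a 3.3-fold lower number from compound 2 to compound 3 (0.52 log units; beyond the scatter), and exchanging the two methoxy groups for a single hydroxy gave a 2.0-fold lower number from compound 1 to compound 3 (0.31 log units; beyond the scatter). Compound 4 keeps one methoxy and carries the hydroxy that compound 3 has, so the step from compound 1 is expected to fall in the same direction as the step to compound 3, modest and toward a lower number; because the step from compound 1 to compound 3 was a 2.0-fold lower number from compound 1 to compound 3 (0.31 log units; beyond the scatter), a similar size is expected here, written as a 1.9-fold lower number from compound 1 to compound 4 (0.27 log units; within the scatter).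

Compound 4 is therefore estimated at 900 nM in this assay, with a range from 400 nM to 2000 nM.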

Compound 4, half-maximal inhibitory concentration: 3780 nM
Estimate against measurement, compound 4: 4.2-fold (0.62 log units) below; measured number outside the range, above it.
By their numbers in this assay, from the lowest: compound 3; then compounds 1, 2 and 4 (each within the scatter of the next, the first and the last beyond it).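

At this position, the hydroxy does not bring a lower number on its own: in this assay, adding a methoxy to the 4-hydroxyphenyl ring gives a 4.6-fold higher number from compound 3 to compound 4 (0.66 log units; beyond the scatter) and removes the gain that the hydroxy showed on the plain phenyl ring. The swap from 2,4-dimethoxyphenyl to 4-hydroxy-3-methoxyphenyl gives a 2.3-fold higher number from compound 1 to compound 4 (0.35 log units; beyond the scatter) and so runs the opposite way to the swap to 4-hydroxyphenyl, while a 1.4-fold higher number from compound 2 to compound 4 (0.14 log units; within the scatter) leaves the ring carrying both groups indistinguishable from plain phenyl. The effect of the hydroxy here therefore depends on what else the ring carries, and nothing available explains why the added methoxy has this effect.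

The compounds shown leave open whether a methoxy alone, as in a 4-methoxyphenyl ring, would behave like the pair of groups in compound 4. They also leave open whether the low number of compound 3 is specific to the hydroxy or would also appear with an amine or a carboxylic acid in its place on the ring.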